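The source may report more compounds than this note shows. Statements on the series, on what has been measured and on what is new or still open speak of the compounds shown alone.

Measured compounds in this series:
compound 1 `COc1ccc(NCCNC(=O)[C@H](CC2CCCCC2)NC(=O)c2ccc(-c3ccc(Cl)cc3)o2)cc1`: 7.1 nM
compound 2 `COc1ccc(NCCNC(=O)[C@H](CC2CCCCC2)NC(=O)c2cccc(-c3ccccc3)c2)cc1`: 2.9 nM
compound 3 `COc1ccc(NCCNC(=O)[C@H](CC(C)(C)C)NC(=O)c2cccc(C)c2)cc1`: 46 nM

All three were tested in an assay on isolated protein for inhibition of cathepsin S (Homo sapiens), at 37 degrees C, at pH 5.5; on this read-out lower numbers stand for stronger inhibition and higher numbers for weaker inhibition. Compound 1 stands second highest of the three numbers: compound 2 sits nearest, with a change of a 2.4-fold lower number from compound 1 to compound 2 (0.39 log units; beyond the scatter), while compound 3 lies furthest away with the highest number of the set.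

The unmeasured compound 4 `COc1ccc(NCCNC(=O)[C@H](CC2CCCCC2)NC(=O)c2ccc(-c3ccccc3)cc2)cc1` differs from compound 1 in one place: 4-phenylphenyl in place of 5-(4-chlorophenyl)furan-2-yl on a carbonyl carbon. Going by the values given here, the only measured step that bears on this change is the one from compound 1 to compound 2, where 3-phenylphenyl replaced the same 5-(4-chlorophenyl)furan-2-yl and gave a 2.4-fold lower number from compound 1 to compound 2 (0.39 log units; beyond the scatter), a modest gain that lies beyond the scatter. Among the compounds with values here, compound 4 carries 4-phenylphenyl instead, for which no direct step is recorded, so the expectation rests on that single analogy. A step of similar direction but smaller size, possibly within the scatter, is therefore expected for compound 4, namely a 1.6-fold lower number from compound 1 to compound 4 (0.20 log units; within the scatter). Compound 4 is accordingly estimated at 4.5 nM in this assay, with a range from 1.5 nM to 14 nM.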

Compound 4, inhibition constant: 9.1 nM
The estimate for compound 4 lay 2.0-fold (0.31 log units) below the measured number; the range from low to high includes it.
By their numbers in this assay, from the lowest: compound 2; then compounds 1 and 4 (each within the scatter of the next); then compound 3.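

In this assay the exchange of 5-(4-chlorophenyl)furan-2-yl for 4-phenylphenyl on the carbonyl carbon gives no readable change (a 1.3-fold higher number from compound 1 to compound 4 (0.11 log units; within the scatter)), so at this position a biaryl group made only of carbon rings stands level with the furan-containing, chlorinated one. Going by these compounds alone, the arrangement of the two phenyl rings, which the earlier compounds could not show, does separate the values: moving from 3-phenylphenyl to 4-phenylphenyl costs a modest amount beyond the scatter (a 3.1-fold higher number from compound 2 to compound 4 (0.50 log units; beyond the scatter)), and the gain seen with 3-phenylphenyl does not extend to its 4-phenylphenyl isomer. No evidence at hand accounts for this difference. On these data alone, it remains open whether a chlorine on 3-phenylphenyl or a pyridine ring in place of one of its phenyl rings would keep the value of compound 2. Whether the same order of the two isomers holds with the side chain of compound 3 is also unsettled.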